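The source may hold more compounds than are shown below. What is called first, only, known or untested is meant among the compounds shown, and "the series" means these compounds.

Among the measured compounds shown here, compound 3 `COc1cc(-c2cc(/C=C/C(=O)c3ccc(Cl)c(Cl)c3)[nH]n2)cc(OC)c1OC` is one of three compounds measured in a functional assay on K562 cells (Homo sapiens) for cytotoxicity, read by sulforhodamine B assay, with a stated time of 48 h, tested at 0.01 uM; a lower number here means a stronger effect, a higher number a weaker effect of the compound at the concentration tested. Compound 3 gives 99% there, and the other two sit close to it: compound 1 `COc1ccc(-c2cc(/C=C/C(=O)c3ccc(N)cc3)[nH]n2)cc1` gives 98% and compound 2 `COc1cc(-c2cc(/C=C/C(=O)c3ccc(N)cc3)[nH]n2)cc(OC)c1OC` gives 100% in this assay. All three numbers lie within the scatter of one another, so no one of them can be set above or below the others.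

Compound 4 `COc1cc(-c2cc(/C=C/C(=O)c3ccc(F)c(F)c3)[nH]n2)cc(OC)c1OC` is not yet measured. It differs from compound 3 in one place: 3,4-difluorophenyl in place of 3,4-dichlorophenyl on a carbonyl carbon

For the measured compounds named here, the only measured step that bears on the carbonyl-attached ring is the one that is also the only step between these compounds, a number 1 percentage points lower from compound 2 to compound 3 (within the scatter), and that step lay within the scatter. For compound 4 he therefore expects a step of about a number 1 percentage points lower from compound 3 to compound 4 (within the scatter) in this assay, that is none beyond the scatter. His estimate for compound 4 is 98%, with a range from 88% to 106%.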

Compound 4, a percentage reported as activity, at one concentration (the size of the read-out at that concentration, not a potency): 100%
Compound 4: middle estimate off by 2 percentage points, on the low side; the measured number falls inside the stated range.
By their numbers in this assay, from the lowest: compounds 1, 3, 2 and 4 (each within the scatter of the next).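

In this assay, the change from 3,4-dichlorophenyl to 3,4-difluorophenyl on the carbonyl carbon gave a number 1 percentage points higher from compound 3 to compound 4 (within the scatter), so exchanging the two chlorine atoms for two fluorine atoms adds a second change at this position that stays inside the scatter. Setting 3,4-difluorophenyl in place of 4-aminophenyl gave no change at the digits printed from compound 2 to compound 4 (within the scatter), which means that 4-aminophenyl, 3,4-dichlorophenyl and 3,4-difluorophenyl cannot be told apart at this position in this assay. No evidence is available that would account for this result.

These compounds leave open whether a phenyl ring carrying a nitrile or a carboxylic acid at this carbonyl carbon would give a number beyond the scatter. They also leave open whether the three rings would still be indistinguishable at any other concentration.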